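The source may report more compounds than this note shows. Statements on the series, on what has been measured and on what is new or still open speak of the compounds shown alone.

Of the compounds shown here, two have been measured so far. Compound 1, `O=C(CN(c1nc(Cl)nc2[nH]cnc12)C1CC1)N[C@@H](CC(=O)OCc1ccccc1)C(=O)OCc1ccccc1`, gives 6.68% in a functional assay on the whole organism (Tail, strain ICR) with Mus musculus as the target, in the tail flick test, with a stated time of 150 min, at a dose of 25 umol/kg by the oral route; a higher number here means a stronger effect of the compound at the dose given, a lower number a weaker effect. Compound 2, `O=C(CN(c1ncnc2c1ncn2C1CCCCO1)C1CC1)NCC(=O)OCc1ccccc1`, gives 7.26% in this assay. Compound 1 stands at the lower of the two numbers, but compound 2 lies within the scatter of it, so the two cannot be told apart. Compound 3, `NC(=O)CC[C@H](NC(=O)CN(c1nc(Cl)nc2[nH]cnc12)C1CC1)C(=O)OCc1ccccc1`, has not yet been measured in this assay. It differs from compound 1 by carbamoylmethyl in place of benzyloxycarbonyl on a saturated chain carbon, two bonds along the chain from an amide-type nitrogen and a carbonyl carbon. For the measured compounds named here, no step between two measured compounds is known, so there is nothing that points in either direction for this change. With both measured compounds at low values, the expectation for compound 3 is that the step of a number 0.3 percentage points higher from compound 1 to compound 3 (within the scatter) stays within the scatter, neither up nor down beyond it. Compound 3 is therefore estimated at 7%, with a range from 0% to 20%.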

Compound 3, a percentage reported as activity, at one dose (the size of the read-out at that dose, not a potency): 31.1%
Compound 3: middle estimate off by 24.1 percentage points, on the low side; measured number above the stated range.
By their numbers in this assay, from the lowest: compounds 1 and 2 (each within the scatter of the next); then compound 3.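

In this assay, the group on this saturated chain carbon, two bonds along the chain from an amide-type nitrogen and a carbonyl carbon, proves to matter: carbamoylmethyl in place of benzyloxycarbonyl gives a number 24.4 percentage points higher from compound 1 to compound 3 (beyond the scatter). For the compounds shown here, this is the first step to lie beyond the scatter, and it shows that the read-out at this dose can change with this position while the rest of compound 1 stays the same. No evidence is available on what lies behind the step.

From the compounds shown here alone, the step rests on a single pair, so it remains open whether the gain belongs to carbamoylmethyl itself or simply follows the loss of benzyloxycarbonyl. A plain methyl, a carboxylic acid or a longer chain ending in the same amide at this place would help separate these two readings.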